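This account rests on a few compounds, and the source may have more. Where it says the series, first, only, none or still open, it means among the compounds named here.

Two fatty amides have been tested in an ADME assay on HaCaT cells (Homo sapiens) for cytotoxicity, read by sulforhodamine B assay, with a stated time of 48 h (a lower number here means that less compound is tolerated, a higher number that more compound is tolerated), so far. Compound 1, `CCCCCCCCCCCCCCCCCC(=O)N1CCOCC1`, carries a long saturated chain joined through a carbonyl to a morpholin-4-yl ring; in this assay compound 1 gives 41.5 ug/mL, the highest of the two numbers, so the cells tolerate more of it than of its neighbour. Compound 2, `CCCCC/C=C\C/C=C\CCCCCCCC(=O)N1CCCCC1`, has an unsaturated chain and a piperidin-1-yl ring, and in this assay compound 2 gives 4.2 ug/mL, a number far enough below compound 1 to lie beyond the scatter of the method.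

Compound 3, `CCCCCCCCCCCCCCCCCC(=O)N1CCCC1`, keeps the saturated chain of compound 1 and changes only the ring: pyrrolidin-1-yl in place of morpholin-4-yl on a carbonyl carbon. Among the compounds with values here, no measured pair shows this exact change, so the direction can only be guessed. Compound 2 shows that a ring without the oxygen can go with a much lower number, but its chain differs too. A modest step downward from compound 1 is expected, a 1.7-fold lower number from compound 1 to compound 3 (0.22 log units; within the scatter), not far beyond the scatter. Compound 3 is estimated to give 25 ug/mL, between 10 ug/mL and 60 ug/mL.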

Compound 3, concentration lethal to 50% of the cells: 6.3 ug/mL
The estimate for compound 3 lay 4.0-fold (0.60 log units) above the measured number, and the stated range ends above it.
By their numbers in this assay, from the lowest: compounds 2 and 3 (each within the scatter of the next); then compound 1.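

In this assay, within the data shown here, the ring on the carbonyl carbon proves to matter on its own: with the saturated chain unchanged, pyrrolidin-1-yl in place of morpholin-4-yl gives a 6.6-fold lower number from compound 1 to compound 3 (0.82 log units; beyond the scatter) and this is the first change in the set that can be read at a single place. The earlier gap between compound 1 and compound 2 could not be assigned to either part, as ring and chain both differed, but a change of ring alone is now seen to move the number beyond the scatter. Nothing measured here accounts for the cells tolerating less of compound 3, so the step stands as an observation without a stated cause.

Still open, from the compounds shown here alone, is whether the step follows the loss of the ring oxygen or the change from a six-membered to a five-membered ring, a question that a piperidin-1-yl ring on the same saturated chain would help to separate. Also open, going by these compounds, is whether the step carries over to the unsaturated chain of compound 2, or how a piperazin-1-yl ring, with a second nitrogen in place of the oxygen, or a shorter saturated chain would fare.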